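A few compounds are considered here, and "the series" means these few. Any claim that something is new, unique, unknown or untested is made for them only; others in the source may bear on it.

Compound 1 `O=C(NCCCCl)Nc1ccc(I)cc1` in a functional assay on MCF7 cells (Homo sapiens) for antiproliferative activity, with a stated time of 48 h (a higher number here means a weaker inhibitor, a lower number a stronger inhibitor), gives only a limit of the assay, > 100000 nM.
Compound 2 `CC(C)(C)c1ccc(NC(=O)NCCCCl)cc1` in this assay gives 49000 nM.
Compound 3 `O=C(CCCl)Nc1ccc(I)cc1` in this assay gives 26000 nM.

Compound 1 and compound 2 share a core and differ in one place, (tert-butyl in place of iodo on an aromatic carbon). The step is an at least 2.0-fold lower number from compound 1 to compound 2 (0.30 log units; that floor lies within the scatter); it is only a floor because compound 1 sits at the limit of > 100000 nM in this assay, at which 1 of the 3 values shown sits. Compound 1 and compound 3 differ in the core itself, (2-chloroethyl in place of (3-chloropropyl)amino on a carbonyl carbon), and the step there is an at least 3.8-fold lower number from compound 1 to compound 3 (0.58 log units; beyond the scatter). The numbers of compound 3 and compound 2 lie within the scatter of one another.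

Compound 4 `CC(C)(C)c1ccc(NC(=O)CCCl)cc1` has not been measured in this assay. It carries the core of compound 3 and differs from it by tert-butyl in place of iodo on an aromatic carbon. This is the same kind of change as that from compound 1 to compound 2, though not the same: in compound 4 the group enters para to a group of 6 heavy atoms, whereas in compound 2 it enters para to a group of 8 heavy atoms. Within the data shown here, the only measured instance of this change is an at least 2.0-fold lower number from compound 1 to compound 2 (0.30 log units; that floor lies within the scatter), a floor rather than a full step, so the expectation rests on thin ground. Compound 4 is expected to give a step of a 1.7-fold lower number from compound 3 to compound 4 (0.24 log units; within the scatter) in this assay. The estimate for compound 4 is 15000 nM, expected to fall between 5000 nM and 40000 nM.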

Compound 4, half-maximal inhibitory concentration: 49000 nM
Compound 4: the middle estimate sits 3.3-fold (0.51 log units) below what was measured, and the stated range ends below it.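

In this assay, tert-butyl in place of iodo gives a 1.9-fold higher number from compound 3 to compound 4 (0.28 log units; within the scatter), so this change does not carry over as a fixed step from the core of compound 1 to the core of compound 3: the same change on two cores in this assay, an at least 2.0-fold lower number (0.30 log units; that floor lies within the scatter) from compound 1 to compound 2 and a 1.9-fold higher number (0.28 log units; within the scatter) from compound 3 to compound 4, at least 3.8-fold (0.58 log units) apart, beyond the scatter of two such steps. Likewise, 2-chloroethyl in place of (3-chloropropyl)amino gives no change at the digits printed from compound 2 to compound 4 (within the scatter) when tert-butyl is present, so that change does not transfer as a fixed step either: the same change on two cores in this assay, an at least 3.8-fold lower number (0.58 log units; beyond the scatter) from compound 1 to compound 3 and no change at the digits printed (within the scatter) from compound 2 to compound 4, at least 3.8-fold (0.58 log units) apart, beyond the scatter of two such steps. Both gaps are only minimum sizes, and they do not show how far the steps truly differ, since each rests on a single pair of steps and on compound 1, whose reading is a limit of the assay and not a number: the limit of > 100000 nM in this assay, at which 1 of the 4 values shown sits.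

The compounds shown leave open whether the same dependence on the core would hold for other groups in place of iodo, such as a methoxy group, an amine or a carboxylic acid. They also leave open how a longer chain than 3-chloropropyl, or a hydroxyl group in place of the chlorine at the end of the chain, would fare on either core.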